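Methoxy to methyl at the aromatic carbon: compound 1 to compound 4

The compounds below may be only part of what the source reports. "The series", "measured", "known", "first", "only" and "open" are said of these compounds alone.

Measured so far:
compound 1 `C=CCOc1c(C)c(C)c2c(c1C)CCC(C)(COc1ccc(/C=C3\SC(=O)NC3=O)cc1OC)O2`: 5%
compound 2 `C=CCOc1c(C)c(C)c2c(c1C)CCC(C)(COc1cccc(/C=C3\SC(=O)NC3=O)c1)O2`: 92%
compound 3 `CC(C)=CCOc1c(C)c(C)c2c(c1C)CCC(C)(COc1ccc(/C=C3\SC(=O)NC3=O)cc1F)O2`: 87%

In a functional assay on MCF7 cells (Homo sapiens), tested at 5 uM (a higher number here means a weaker effect of the compound at the concentration tested, a lower number a stronger effect), compound 1 stands lowest of the three numbers with 5%. Compound 3 gives 87% and compound 2 gives 92%, each beyond the scatter above compound 1. Compound 4 `C=CCOc1c(C)c(C)c2c(c1C)CCC(C)(COc1ccc(/C=C3\SC(=O)NC3=O)cc1C)O2` differs from compound 1 in one place: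
methyl in place of methoxy on an aromatic carbon
For the measured compounds named here, no measured pair isolates this change, and the two variants of compound 1 that exist both sit far higher, so the outcome is open. A step of moderate size toward a weaker effect is expected, a number 45 percentage points higher from compound 1 to compound 4 (beyond the scatter), with wide uncertainty in both directions. For compound 4 the expected value is 50%, in the range 8% to 92%.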

Compound 4, a percentage reported as activity, at one concentration (the size of the read-out at that concentration, not a potency): 24%
For compound 4 the middle estimate is 26 percentage points above the measured one; the range from low to high includes it.
By their numbers in this assay, from the lowest: compound 1; then compound 4; then compounds 3 and 2 (each within the scatter of the next).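

In this assay the step of a number 19 percentage points higher from compound 1 to compound 4 (beyond the scatter) is what this change costs at the aromatic carbon ortho to a large group. The oxygen of the methoxy is therefore not needed for a marked effect at the concentration tested, since compound 4 with only a methyl still reads 24%. Nothing at hand explains the size of this step.

Still open, on these data alone, is how a hydroxyl, an amine or a chlorine would behave on this carbon. As far as these compounds go, whether the methoxy-to-methyl step holds with other ether chains on the shared core also remains open.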